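Inhibition in the rat: fluoro for cyano on the aryl ring

The source may report more compounds than this note shows. Statements on the series, on what has been measured and on what is new or still open speak of the compounds shown alone.

Measured compounds:
compound 1 `N#Cc1cccc(F)c1-c1nc2ncccc2o1` — 50%
compound 2 `N#Cc1cccc(C#N)c1-c1nc2ncccc2o1` — 19%
compound 3 `N#Cc1ccccc1-c1nc2ncccc2o1` — 62%

In a functional assay on the whole organism for inhibition, with Rattus norvegicus as the target, at a dose of 30 mg/kg (on this read-out lower numbers stand for less inhibition and higher numbers for more inhibition at the one dose given (going by the name of the read-out)), compound 1 stands second highest of the three; compound 3 lies above it and compound 2 well below it. The next step goes from compound 1 to compound 4 `Fc1cccc(F)c1-c1nc2ncccc2o1` by fluoro in place of cyano on an aromatic carbon. Going by the values given here, two measured steps bear on it. Removing a cyano gave a number 43 percentage points higher from compound 2 to compound 3 (beyond the scatter), and putting a cyano in place of fluoro gave a number 31 percentage points lower from compound 1 to compound 2 (beyond the scatter); removing a fluoro gave only a number 12 percentage points higher from compound 1 to compound 3 (beyond the scatter). Taking the cyano out of compound 1 is therefore expected to raise inhibition in this assay, roughly a number 18 percentage points higher from compound 1 to compound 4 (beyond the scatter). For compound 4 the value in this assay is estimated at 68%, within 48% to 88%.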

Compound 4, a percentage reported as inhibition, in the whole organism at one dose (the size of the read-out at that dose, not a potency): 66%
Compound 4: the middle estimate sits 2 percentage points above what was measured, within the range that was stated.
By their numbers in this assay, from the lowest: compound 2; then compound 1; then compounds 3 and 4 (each within the scatter of the next).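

In this assay, fluoro in place of cyano on this aromatic carbon, ortho to a group of 9 heavy atoms, gives a number 16 percentage points higher from compound 1 to compound 4 (beyond the scatter). The earlier compounds shown here showed a cyano lowering the number only where it replaced fluoro, in a number 31 percentage points lower from compound 1 to compound 2 (beyond the scatter); the new step shows the reverse exchange raising the number at the position that carries cyano in both of those compounds. No measurement here accounts for the change.

Still open, on these data alone, is how an amine, a methoxy group or a carboxylic acid on this carbon would compare with fluoro. Also open, as far as these compounds go, is whether hydrogen here, with the other fluoro kept, would read differently from fluoro at the one dose given.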